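This account rests on a few compounds, and the source may have more. Where it says the series, first, only, none or still open, it means among the compounds named here.

Compound 1, `CC1=C(N2CC2)C(=O)C(C(C)COC(N)=O)=C(N2CC2)C1=O`, gives 5.31 in a functional assay on L1210 cells (Mus musculus), with a stated time of 1 days; on this read-out higher numbers stand for higher potency (the scale is a negative logarithm) and lower numbers for lower potency.
Compound 2, `CC1=C(N2CC2)C(=O)C(CCC(=O)N(C)C)=C(N2CC2)C1=O`, gives 4.84.
Compound 3, `CC1=C(N2CC2)C(=O)C(N2CC2)=C(N2CC2)C1=O`, gives 5.69.

Compound 1 stands second highest of the three, with compound 3 above it by a number 0.38 log units higher from compound 1 to compound 3 (beyond the scatter) and compound 2 below it by a number 0.47 log units lower from compound 1 to compound 2 (beyond the scatter). Compound 4, `CCC(COC(N)=O)C1=C(N2CC2)C(=O)C(C)=C(N2CC2)C1=O`, differs from compound 1 by methyl in place of hydrogen on a saturated chain carbon, two bonds along the chain from a double-bonded ring carbon. The measured steps all exchange the whole side chain for another group, so none of them bears directly on a small addition along the chain; nothing here shows what such an addition does. The shared core and the carbamate are kept. For compound 4 the expectation is therefore a step of a number 0.01 log units lower from compound 1 to compound 4 (within the scatter), within the scatter. Compound 4 is estimated at 5.3, between 4.8 and 5.8.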

Compound 4, logarithm of the reciprocal of the active concentration, log(1/C): 5.2
Compound 4: the middle estimate sits 0.10 log units above what was measured, within the range that was stated.
By their numbers in this assay, from the lowest: compound 2; then compounds 4 and 1 (each within the scatter of the next); then compound 3.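

In this assay, methyl in place of hydrogen on a saturated chain carbon, two bonds along the chain from a double-bonded ring carbon, gives a number 0.11 log units lower from compound 1 to compound 4 (within the scatter). This position therefore accepts the change from methyl to ethyl with no difference that can be told from scatter, something the earlier whole-side-chain exchanges could not show. No measurement here offers an explanation for this result.

Still open, from the compounds shown here alone, is whether a longer chain such as propyl would be accepted at this carbon as well. Going by these compounds, an amine there is equally open.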